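A Bromine Replaces Two Fluorines on the Benzyl Arm

The source may hold more compounds than are shown below. What is called first, only, known or untested is meant among the compounds shown, and "the series" means these compounds.

Three compounds built on one shared core were measured in an assay on isolated protein for inhibition of protein deacetylase HDAC6 (Homo sapiens), read by fluorescence, with a stated time of 1 h, tested at 100 nM; on this read-out lower numbers stand for less inhibition and higher numbers for more inhibition at the one concentration tested (going by the name of the read-out). Compound 1 `O=C(/C=C/c1ccc(OCc2nc(C3CCN(Cc4ccccc4)CC3)no2)cc1)NO` gives 71%. Compound 2 `O=C(/C=C/c1ccc(OCc2nc(C3CCN(Cc4cccc(F)c4)CC3)no2)cc1)NO` gives 73%. Compound 3 `O=C(/C=C/c1ccc(OCc2nc(C3CCN(Cc4ccc(F)c(F)c4)CC3)no2)cc1)NO` gives 60%, the lowest of the three numbers. The step of a number 11 percentage points lower from compound 1 to compound 3 (beyond the scatter) and the step of a number 13 percentage points lower from compound 2 to compound 3 (beyond the scatter) both lie beyond the scatter, whereas the step of a number 2 percentage points higher from compound 1 to compound 2 (within the scatter) does not, so a single fluoro on that aromatic ring left the number unchanged and a second fluoro came with a modest drop.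

Compound 4 `O=C(/C=C/c1ccc(OCc2nc(C3CCN(Cc4ccc(Br)cc4)CC3)no2)cc1)NO` is the next compound in this line. It differs from compound 3 in one place: 4-bromophenyl in place of 3,4-difluorophenyl on a saturated chain carbon bound to an amine nitrogen in a ring. Among the measured compounds shown here, both fluorines leave and a bromine enters; no measured compound carries bromine, so there is no direct step for it. For the measured compounds named here, the steps that bear on the change are those from compound 1 and compound 2 to compound 3, each of which ran downward by a modest amount when the second fluoro arrived. Removing both fluorines in compound 4 is therefore expected to carry the number in this assay back up toward where compound 1 and compound 2 stand, a modest rise of about a number 8 percentage points higher from compound 3 to compound 4 (within the scatter). Compound 4 is estimated at 68%, with a likely range from 55% to 80%.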

Compound 4, a percentage reported as inhibition, at one concentration (the size of the read-out at that concentration, not a potency): 58%
The estimate for compound 4 lay 10 percentage points above the measured number; low and high end bracket the measured number.
By their numbers in this assay, from the lowest: compounds 4 and 3 (each within the scatter of the next); then compounds 1 and 2 (each within the scatter of the next).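

In this assay, taking both fluorines away and bringing in a bromine gives no separation between the two groups: the step of a number 2 percentage points lower from compound 3 to compound 4 (within the scatter) leaves 3,4-difluorobenzyl and 4-bromobenzyl indistinguishable on this read-out. Among the compounds shown here, compound 4 also adds something that the fluorine series could not show, since the single bromo on the benzyl ring gives a step of a number 13 percentage points lower from compound 1 to compound 4 (beyond the scatter) and the change from the single-fluoro ring gives a step of a number 15 percentage points lower from compound 2 to compound 4 (beyond the scatter), so a drop at this position is not tied to carrying two fluorines, although the single fluoro of compound 2 goes against any rule that every halogen on this ring lowers the number. No accompanying evidence explains why these ring changes read as they do.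

The compounds shown leave open whether 4-fluorophenyl or 4-chlorophenyl would read like 4-bromophenyl, which would separate the effect of the kind of halogen from that of where it stands on the ring. They also leave open how a ring carrying a methoxy group or a nitrile, neither of them a halogen, would compare with the plain benzyl of compound 1.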